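A few compounds are considered here, and "the series" means these few. Any claim that something is new, unique, unknown or untested is made for them only; others in the source may bear on it.

Of the compounds shown here, three have so far been measured in a functional assay on HEK293 cells for agonist activity at growth hormone secretagogue receptor type 1 (Homo sapiens), read by HTRF and inositol phosphate accumulation, with a stated time of 90 min, in the presence of a further agent that is not named here; a lower number here means a smaller maximal response, a higher number a larger maximal response. Compound 1 `Cc1ccc2[nH]c(C(=O)N[C@H]3CN(S(=O)(=O)c4ccccc4)C[C@@H]3C(=O)NC[C@H]3CCCN3C)cc2c1` gives 98%, and compound 2 `Cc1ccc2[nH]c(C(=O)N[C@H]3CN(S(=O)(=O)c4ccccc4)C[C@@H]3C(=O)N[C@H]3CCCN(C)C3)cc2c1` gives 99%. Compound 3 `Cc1oc(-c2ccc(Cl)cc2)nc1C(=O)N[C@H]1CN(S(=O)(=O)c2ccccc2)C[C@@H]1C(=O)N[C@H]1CCCNC1` gives 87%, the lowest of the three numbers, and its gaps to compound 1 and to compound 2 both lie beyond the usual scatter of such measurements. Within the data shown here, the only step between two measured compounds that differ in a single place is a number 1 percentage points higher from compound 1 to compound 2 (within the scatter); it exchanges the group on an amide-type nitrogen and leaves the aromatic part untouched, so it says little about the change considered here.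

Compound 4 `Cc1oc(-c2ccc(C(F)(F)F)cc2)nc1C(=O)N[C@H]1CN(S(=O)(=O)c2ccccc2)C[C@@H]1C(=O)N[C@H]1CCCNC1` differs from compound 3 in one place: trifluoromethyl in place of chloro on an aromatic carbon. Among the measured compounds shown here, no measured pair shows what such an exchange does in this assay, so the expectation rests on compound 3 alone and carries a wide range. The step is expected to be no change at the digits printed from compound 3 to compound 4 (within the scatter), that is, nothing beyond the scatter. For compound 4 the expected value in this assay is 87%, within a range from 74% to 100%.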

Compound 4, largest response reached (Emax), in percent of the reference or control that the assay uses in the growth hormone secretagogue receptor type 1 assay: 85%
Beside the measured number, compound 4's estimate is 2 percentage points above it; the range from low to high includes it.
By their numbers in the growth hormone secretagogue receptor type 1 assay, from the lowest: compounds 4 and 3 (each within the scatter of the next); then compounds 1 and 2 (each within the scatter of the next).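

In the growth hormone secretagogue receptor type 1 assay the step is a number 2 percentage points lower from compound 3 to compound 4 (within the scatter), so on this aromatic carbon, para to a large group, trifluoromethyl with its 4 heavy atoms can replace chloro with its 1 without moving the maximal response beyond the scatter. In a physicochemical assay for lipophilicity, measured as octanol-water partition, at pH 7.4 (on this read-out higher numbers stand for higher lipophilicity and lower numbers for lower lipophilicity), compound 3 gives 2 and compound 4 gives 2.3, which is a number 0.30 log units higher from compound 3 to compound 4 (within the scatter), so this exchange also shifts the distribution coefficient no further than the scatter. Nothing measured here gives a reason for either result.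

On these data alone, what an amine or a carboxylic acid at this aromatic carbon would do remains open, since both groups compared here have no hydrogen-bond donors or acceptors. Also open, as far as these compounds go, is how the same exchange would read with another group on the amide-type nitrogen, such as 1-methylpiperidin-3-yl.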